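Triazolylmethyl ester series on a shared core: phenyl swap

The compounds below may be only part of what the source reports. "The series", "measured", "known", "first", "only" and "open" are said of these compounds alone.

The series shares the core of compound 1 `C/C(=C\CC/C(C)=C/CC[C@@H]1[C@@]2(C)CCC(=O)C(C)(C)[C@H]2CC[C@@]1(C)O)CC/C=C(\C)C(=O)OCc1cn(-c2ccc(Br)cc2)nn1`, a triazolylmethyl ester of the parent acid compound 2 `C/C(=C\CC/C(C)=C/CC[C@@H]1[C@@]2(C)CCC(=O)C(C)(C)[C@H]2CC[C@@]1(C)O)CC/C=C(\C)C(=O)O`. Both were run in a functional assay on A549 cells (Homo sapiens) for antiproliferative activity, read by MTT assay, with a stated time of 48 h; on this read-out higher numbers stand for weaker inhibition and lower numbers for stronger inhibition. In this assay compound 1 gives > 150000 nM, which is a limit of the assay and not a number. In this assay compound 2 gives > 150000 nM, again a limit rather than a measured value. Compound 1 therefore stands exactly where every value shown stands: the limit of > 150000 nM in this assay, at which 2 of the 2 values shown sit. Within the data shown here, no ordering among the measured compounds can be drawn and no step between them is counted.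

Compound 3 `C/C(=C\CC/C(C)=C/CC[C@@H]1[C@@]2(C)CCC(=O)C(C)(C)[C@H]2CC[C@@]1(C)O)CC/C=C(\C)C(=O)OCc1cn(-c2cccc(C)c2)nn1` differs from compound 1 in one place: 3-methylphenyl in place of 4-bromophenyl on an aromatic nitrogen. Among the measured compounds shown here, no measured step covers such a change, and nothing in the numbers points to a shift beyond the scatter in either direction. The expected step from compound 1 to compound 3 is a step that the limit leaves unreadable from compound 1 to compound 3, that is, none beyond the scatter. Compound 3 is estimated at 200000 nM in this assay, with an expected range from 80000 nM to 600000 nM, most probably reported once more only as a limit.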

Compound 3, half-maximal inhibitory concentration: > 150000 nM
Compound 3: no number, only a limit; the forecaster's own chance of this, stated with the estimate: 85%; the middle value lies beyond the limit too.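

Compound 1 and compound 3 give no readable step in this assay, and a limit is not a number: the limit of > 150000 nM in this assay, at which 3 of the 3 values shown sit.

The compounds shown leave open whether any group on the aromatic nitrogen, or any other change to the shared core, gives a measured value rather than a limit.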